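Methyl in Place of Fluoro on a Shared Core

A few compounds are considered here, and "the series" means these few. Any claim that something is new, unique, unknown or untested is made for them only; others in the source may bear on it.

Of the compounds shown here, three built on one shared core have so far been tested in a functional assay on PC-3 cells (Homo sapiens) for inhibition, read by sulforhodamine B assay, with a stated time of 48 h; on this read-out higher numbers stand for weaker inhibition and lower numbers for stronger inhibition. Compound 2 `COC(=O)[C@@]1(C)C[C@@H](c2coc3ccc(F)cc3c2=O)N(c2ccccc2)O1` gives 31300 nM in this assay. Compound 3 `O=c1c([C@@H]2C[C@H](c3ccccc3)ON2c2ccccc2)coc2cc(Cl)c(Cl)cc12` gives 32000 nM, a number that lies within the usual scatter of the value for compound 2, so no order between these two can be claimed. Compound 1 `CCO[C@H]1C[C@@H](c2coc3ccc(Br)cc3c2=O)N(c2ccccc2)O1` returns only a limit, > 60000 nM, and therefore supplies no number at all. Among the two numbers available, compound 2 has the lower one, but by a margin that carries no meaning.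

Compound 4 `COC(=O)[C@@]1(C)C[C@@H](c2coc3ccc(C)cc3c2=O)N(c2ccccc2)O1` is the next compound awaiting a result. It differs from compound 2 in one place: methyl in place of fluoro on an aromatic carbon. Going by the values given here, no pair of measured compounds differs in a single place, so the data give no direct reading of how large such a swap tends to be. With the two measured numbers sitting so close together, the expectation is that this change moves the value little, if at all, beyond the scatter. The estimate for compound 4 is 30000 nM, with a range from 12000 nM to 75000 nM. That estimate corresponds to a step of a 1.0-fold lower number from compound 2 to compound 4 (0.02 log units; within the scatter), which is expected to stay within the scatter.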

Compound 4, half-maximal inhibitory concentration: > 60000 nM
Compound 4: no number, only a limit; the forecaster's own chance of this, stated with the estimate: 25%; middle value at least 2.0-fold (0.30 log units) from the limit.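

Methyl in place of fluoro on this aromatic carbon gives the first step between compounds that differ in one place in this assay: it is an at least 1.9-fold higher number from compound 2 to compound 4 (0.28 log units; that floor lies within the scatter). The value for compound 4 is a limit and not a number, so this step has a floor but no known upper end; the change may be small or much larger, and the floor alone does not show that methyl and fluoro differ here beyond ordinary repeat variation. Compound 4 therefore adds a bound rather than an exact size for this swap, and it joins the compounds at which the read-out gives no number: the limit of > 60000 nM in this assay, at which 2 of the 4 values shown sit.

The compounds shown leave open whether a true difference exists at this position, and a single pair cannot establish a trend for other substituents or for the other parts of the shared core. Going by these compounds, how an amine, a methoxy group or a carboxylic acid on that same aromatic carbon would read, and whether any of them would give a number rather than a limit, also remains open.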